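Diacylglycerol lipase-alpha ketones: phenyl to methyl on the chain

A few compounds are considered here, and "the series" means these few. Any claim that something is new, unique, unknown or untested is made for them only; others in the source may bear on it.

Measured so far:
compound 1 `O=C(CCc1ccccc1)c1nc2ncccc2o1` — 18200 nM
compound 2 `O=C(CCCCc1ccccc1)c1nc2ncccc2o1` — 204 nM

In an assay on HEK-293T cells for inhibition of diacylglycerol lipase-alpha (Homo sapiens), read by colorimetric assay (a higher number here means a weaker inhibitor, a lower number a stronger inhibitor), compound 2 gives 204 nM, the lower of the two numbers; compound 1 gives 18200 nM, a gap that lies beyond the scatter. Compound 3 `CCCCCC(=O)c1nc2ncccc2o1` carries the change (methyl in place of phenyl on a saturated chain carbon, four bonds along the chain from a carbonyl carbon). For the measured compounds named here, no measured pair shows this change, so its size is open. The chain stays, the ring goes; an upward step, beyond the scatter, is expected from compound 2 to compound 3, a 15-fold higher number from compound 2 to compound 3 (1.17 log units; beyond the scatter). Compound 3 is expected near 3000 nM, within 500 nM to 15000 nM.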

Compound 3, half-maximal inhibitory concentration: > 10000 nM
Compound 3: a limit, no number (the forecaster's own chance of this, stated with the estimate: 5%); at least 3.3-fold (0.52 log units) between middle value and limit.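

Compound 3 stands at > 10000 nM, a limit of the assay and not a number. Even so, methyl in place of phenyl at this chain position gives an at least 49-fold higher number from compound 2 to compound 3 (1.69 log units; beyond the scatter), so the chain without the phenyl does not keep the level of compound 2, and this position tolerates at least this one change poorly. The step that links compound 1 to compound 3 cannot be read against the limit.

Going by these compounds, whether the phenyl ring can be replaced remains open. A cyclohexyl or pyridyl group at this position, or a longer chain carrying phenyl, would test this.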